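The source may report more compounds than this note shows. Statements on the series, on what has been measured and on what is new or still open speak of the compounds shown alone.

Of the compounds shown here, three of one shared core have been measured in a functional assay on Molt4/C8 cells (Homo sapiens) for cytotoxicity; a lower number here means a stronger inhibitor, a higher number a weaker inhibitor. Compound 1 `COc1ccc(NC(=O)/C=C/C(=O)N2C/C(=C\c3ccc([N+](=O)[O-])cc3)C(=O)/C(=C/c3ccc([N+](=O)[O-])cc3)C2)cc1` gives 940 nM, compound 3 `CC(=O)c1ccc(NC(=O)/C=C/C(=O)N2C/C(=C\c3ccc([N+](=O)[O-])cc3)C(=O)/C(=C/c3ccc([N+](=O)[O-])cc3)C2)cc1` gives 390 nM, and compound 2 `O=C(/C=C/C(=O)N1C/C(=C\c2ccccc2)C(=O)/C(=C/c2ccccc2)C1)Nc1ccc([N+](=O)[O-])cc1` gives 31000 nM. Compound 2 therefore stands highest of the three numbers. Its gap to compound 1 and its gap to compound 3 are both beyond the scatter, and compound 2 is the weakest inhibitor of the three.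

Compound 4 `Cc1ccc(NC(=O)/C=C/C(=O)N2C/C(=C\c3ccccc3)C(=O)/C(=C/c3ccccc3)C2)cc1` differs from compound 2 in one place: methyl in place of nitro on an aromatic carbon.

For the measured compounds named here, no measured pair shows this exact exchange. Going by the values given here, the only step between compounds differing in one place is a 2.4-fold lower number from compound 1 to compound 3 (0.38 log units; beyond the scatter), where one group on the same kind of aromatic carbon gives way to another and the number moves only modestly. Compound 2 differs from compound 1 and compound 3 in more than one place, so what its two nitro-free rings contribute cannot be separated from what the nitro on the anilide ring contributes. The expectation is thus a modest step at most, with no sure direction.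

For compound 4 the estimate is 25000 nM, ranging from 8000 nM to 80000 nM, which would mean a step of a 1.2-fold lower number from compound 2 to compound 4 (0.09 log units; within the scatter).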

Compound 4, half-maximal inhibitory concentration: 660 nM
Beside the measured number, compound 4's estimate is 38-fold (1.58 log units) above it; the measured number lies below the stated range.
By their numbers in this assay, from the lowest: compounds 3, 4 and 1 (each within the scatter of the next, the first and the last beyond it); then compound 2.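

In this assay, methyl in place of nitro gives a 47-fold lower number from compound 2 to compound 4 (1.67 log units; beyond the scatter), so this one place on the aromatic ring, para to a large group, can decide much of what the whole compound does in this assay. For the compounds shown here, the only earlier step at a comparable place, a 2.4-fold lower number from compound 1 to compound 3 (0.38 log units; beyond the scatter), was far smaller, and it was read in compounds that carry nitro on their other two aromatic rings, so a small change there does not predict a small change here, where those two rings are plain. No measurement in hand explains why nitro and methyl differ so widely at this place.

With only nitro and methyl shown on this otherwise plain core, it remains open whether an amine, a carboxylic acid or a chlorine at the same place would give a number closer to compound 2 or to compound 4. From the compounds shown here alone, it is also open whether the same exchange would move the number as far in a compound that keeps nitro on its other two rings, so the size of this step belongs, for now, to this one pair.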